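The source may hold more compounds than are shown below. What is called first, only, known or untested is meant among the compounds shown, and "the series" means these compounds.

Of the compounds shown here, two with a shared core have been tested so far in an ADME assay on BaF3 cells (Mus musculus) for antiproliferative activity, read by CCK-8 assay, with a stated time of 72 h; on this read-out lower numbers stand for stronger inhibition of growth and higher numbers for weaker inhibition of growth: compound 1 (`O=C(CCSc1ccc2c(/C=C/c3ccccn3)n[nH]c2c1)Nc1ccc(Cl)c(C(F)(F)F)c1`) and compound 2 (`COc1ccc(NC(=O)CCSc2ccc3c(/C=C/c4ccccn4)n[nH]c3c2)cc1C(F)(F)F`). Compound 1 gives > 10000 nM, which is a limit of the assay and not a number. Compound 2 gives > 10000 nM, which is likewise a limit, so it has no measured potency to start from. Together the two compounds show only (the limit of > 10000 nM in this assay, at which 2 of the 2 values shown sit).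

Compound 3 (`CCN1CCN(Cc2ccc(NC(=O)CCSc3ccc4c(/C=C/c5ccccn5)n[nH]c4c3)cc2C(F)(F)F)CC1`) changes one group of compound 2: (4-ethylpiperazin-1-yl)methyl in place of methoxy on an aromatic carbon. In words, (4-ethylpiperazin-1-yl)methyl stands in place of methoxy on an aromatic carbon, ortho to a trifluoromethyl group and para to a large group.

Within the data shown here, the one measured step that bears on this is a step that the two limits leave unreadable from compound 1 to compound 2, a swap of chloro for methoxy, and it offers no size to carry over. Among the measured compounds shown here, no tested compound holds the entering group, so any forecast is loose. An estimated at least 1.6-fold lower number from compound 2 to compound 3 (0.22 log units; that floor lies within the scatter) is expected, modest and toward stronger inhibition if it can be read at all. For compound 3 the expected value is 6000 nM, with an estimated range of 1500 nM to 20000 nM, and a further limit would be no surprise.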

Compound 3, concentration for 50% growth inhibition: 840 nM
Beside the measured number, compound 3's estimate is 7.1-fold (0.85 log units) above it; the measured number lies below the stated range.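

In this assay, the aromatic carbon ortho to the trifluoromethyl group turns out to be a place where a change can be read. Putting (4-ethylpiperazin-1-yl)methyl there instead of methoxy gives an at least 11-fold lower number from compound 2 to compound 3 (1.07 log units; beyond the scatter), and putting it there instead of chloro gives an at least 11-fold lower number from compound 1 to compound 3 (1.07 log units; beyond the scatter), both sizes being floors that the real steps may exceed. Compound 3 is the only one of the three compounds to give a measured number, which shows that the shared core can register growth inhibition in this test once this group is in place, while the rest of the set stays at: the limit of > 10000 nM in this assay, at which 2 of the 3 values shown sit.

The step between the two compounds at the limit cannot be read, so chloro and methoxy cannot be ranked against each other. As far as these compounds go, it also remains open which part of the entering group goes with the stronger inhibition, a question that a dimethylaminomethyl group, a morpholin-4-ylmethyl group or the 4-methylpiperazin-1-ylmethyl analogue at the same carbon could help to separate.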